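A few compounds are considered here, and "the series" means these few. Any claim that something is new, unique, unknown or untested is made for them only; others in the source may bear on it.

Of the compounds shown here, three with a shared core have been measured in a functional assay on cells (T-cell, Homo sapiens) for inhibition (on this read-out lower numbers stand for stronger inhibition and higher numbers for weaker inhibition), and they differ only in the group carried on an amine nitrogen in a ring. Compound 1 `COc1ccc(-c2cnc3nc(N)nc(N4CCN(c5cc(Cl)cc(Cl)c5)CC4)c3n2)cc1OC` gives 3400 nM. Compound 2 `COc1ccc(-c2cnc3nc(N)nc(N4CCN(c5ccccc5)CC4)c3n2)cc1OC` gives 400 nM, an improvement of an 8.5-fold lower number from compound 1 to compound 2 (0.93 log units; beyond the scatter). Compound 3 `COc1ccc(-c2cnc3nc(N)nc(N4CCN(C(=O)Nc5cccc(C)c5)CC4)c3n2)cc1OC` gives 7 nM, the lowest of the three numbers: the change from compound 2 brought a 57-fold lower number from compound 2 to compound 3 (1.76 log units; beyond the scatter), and from compound 1 the move was even larger, a 490-fold lower number from compound 1 to compound 3 (2.69 log units; beyond the scatter).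

Compound 4 `COc1ccc(-c2cnc3nc(N)nc(N4CCN(Cc5ccc(C(C)(C)C)cc5)CC4)c3n2)cc1OC` has not yet been tested in this assay. It differs from compound 3 in one place: 4-(tert-butyl)benzyl in place of (3-methylphenyl)carbamoyl on an amine nitrogen in a ring

Within the data shown here, the steps that bear on this are the two leading to compound 3, since both replaced a directly attached aromatic ring with the (3-methylphenyl)carbamoyl group and both produced large gains. Among the measured compounds shown here, compound 4 gives that group up again, but does not return to a directly attached ring either; the 4-(tert-butyl)benzyl group is a third kind of substituent with no measured precedent here. The expectation is therefore a step toward weaker inhibition in this assay, a 29-fold higher number from compound 3 to compound 4 (1.46 log units; beyond the scatter), though smaller than the gap back to compound 2. Compound 4 is estimated at 200 nM, with a range from 30 nM to 1500 nM.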

Compound 4, half-maximal inhibitory concentration: 4300 nM
For compound 4 the middle estimate is 22-fold (1.33 log units) below the measured one; measured number outside the range, above it.
By their numbers in this assay, from the lowest: compound 3; then compound 2; then compounds 1 and 4 (each within the scatter of the next).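

In this assay the change to 4-(tert-butyl)benzyl brings a 610-fold higher number from compound 3 to compound 4 (2.79 log units; beyond the scatter), so the strong inhibition seen with (3-methylphenyl)carbamoyl on this ring nitrogen does not follow from simply having a large group with an aromatic ring: both groups contain one six-membered aromatic ring of carbon only, but the group that leaves has 1 hydrogen-bond donor and 1 hydrogen-bond acceptor, and the group that enters has 0 of each. The plain phenyl group also compares favourably with the new group, as the change to it shows an 11-fold higher number from compound 2 to compound 4 (1.03 log units; beyond the scatter), whereas the comparison with the 3,5-dichlorophenyl group gives a 1.3-fold higher number from compound 1 to compound 4 (0.10 log units; within the scatter), which means compound 1 and compound 4 cannot be told apart in this assay despite their different groups. Nothing available here explains these differences.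

Compound 4 changes the linkage and adds a tert-butyl group at once, so the compounds shown leave open which of these features accounts for its distance from compound 2. An unsubstituted benzyl group would separate those two features, and a benzoyl group, which keeps the carbonyl but lacks the amide hydrogen, would test which part of the carbamoyl group matters.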